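Nitro in place of chloro on the shared core

A few compounds are considered here, and "the series" means these few. Any claim that something is new, unique, unknown or untested is made for them only; others in the source may bear on it.

Measured in an ADME assay on NIH3T3 cells (Mus musculus) for cytotoxicity, read by MTT assay; on this read-out lower numbers stand for stronger inhibition and higher numbers for weaker inhibition:
- compound 1 `N#Cc1c(-c2cccc(Cl)c2)c(C#N)c(=O)n(/N=C/c2cn(-c3ccccc3)nc2-c2ccccc2)c1N`: 52 ug/mL
- compound 2 `N#Cc1c(-c2ccc(Cl)cc2)c(C#N)c(=O)n(/N=C/c2cn(-c3ccccc3)nc2-c2ccccc2)c1N`: 64 ug/mL
- compound 3 `Cc1ccc(-c2c(C#N)c(N)n(/N=C/c3cn(-c4ccccc4)nc3-c3ccccc3)c(=O)c2C#N)cc1`: 98 ug/mL

On these numbers, compound 2 stands inside the scatter of both other compounds. The steps that touch it are a 1.2-fold higher number from compound 1 to compound 2 (0.09 log units; within the scatter) and a 1.5-fold higher number from compound 2 to compound 3 (0.19 log units; within the scatter). For the measured compounds named here, the remaining pair gives a 1.9-fold higher number from compound 1 to compound 3 (0.28 log units; within the scatter), so no measured step exceeds the scatter.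

The next entry is compound 4 `N#Cc1c(-c2ccc([N+](=O)[O-])cc2)c(C#N)c(=O)n(/N=C/c2cn(-c3ccccc3)nc2-c2ccccc2)c1N`, which has nitro in place of chloro on an aromatic carbon, para to a large group: nitro in place of chloro on an aromatic carbon.

The closest evidence is the exchange at the same place, methyl in place of chloro on an aromatic carbon: a 1.5-fold higher number from compound 2 to compound 3 (0.19 log units; within the scatter). The change from 3-chlorophenyl to 4-chlorophenyl also bears on it: a 1.2-fold higher number from compound 1 to compound 2 (0.09 log units; within the scatter). Going by the values given here, no nitro compound has been measured, so this exchange itself is untested, and the range has to stay wide. With every measured step inside the scatter, no step beyond the scatter is expected in this assay, and no direction can be assigned.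

For compound 4 the estimated value is 70 ug/mL, with an expected range of 35 ug/mL to 130 ug/mL.

This estimate means an expected 1.1-fold higher number from compound 2 to compound 4 (0.04 log units; within the scatter).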

Compound 4, half-maximal inhibitory concentration: 84 ug/mL
Beside the measured number, compound 4's estimate is 1.2-fold (0.08 log units) below it; measured number inside the range.
By their numbers in this assay, from the lowest: compounds 1, 2, 4 and 3 (each within the scatter of the next).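

In this assay, the place that held chloro or methyl now carries nitro, and nitro in place of chloro gives a 1.3-fold higher number from compound 2 to compound 4 (0.12 log units; within the scatter), while nitro in place of methyl gives a 1.2-fold lower number from compound 3 to compound 4 (0.07 log units; within the scatter). Chloro, methyl and nitro on this aromatic carbon, para to a large group, are therefore not separated by this read-out, and the comparison with the 3-chlorophenyl compound, a 1.6-fold higher number from compound 1 to compound 4 (0.21 log units; within the scatter), does not separate the 4-nitrophenyl group from that group either. Nothing available accounts for this flat response.

Still open, from the compounds shown here alone, is whether a group of another type at this place, such as an amine, a carboxylic acid or a longer chain, would give a step beyond the scatter. Also open, going by these compounds, is whether these four compounds would separate on any cells other than those of this assay.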